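Cytotoxicity notes: nitro for fluoro on the anilide ring

A few compounds are considered here, and "the series" means these few. Any claim that something is new, unique, unknown or untested is made for them only; others in the source may bear on it.

Measured so far in an ADME assay on MT4 cells (Homo sapiens) for cytotoxicity, read by MTT assay; a higher number here means that more compound is tolerated, a lower number that less compound is tolerated: compound 1 `Cc1ccc(NC(=O)CSc2nccn2-c2cccc3ccccc23)c(Br)c1` gives 29400 nM; compound 2 `O=C(CSc1nccn1-c1cccc2ccccc12)Nc1ccccc1F` gives 34700 nM.

Compound 2 stands highest of the two numbers, though the step of a 1.2-fold higher number from compound 1 to compound 2 (0.07 log units; within the scatter) is within the scatter, so no order can be read between the two. Compound 3 `O=C(CSc1nccn1-c1cccc2ccccc12)Nc1ccccc1[N+](=O)[O-]` differs from compound 2 by nitro in place of fluoro on an aromatic carbon. For the measured compounds named here, the only measured step bears on it loosely, as a change on the same anilide ring, and it was within the scatter. No step beyond the scatter is therefore expected in this assay; the step of a 1.1-fold lower number from compound 2 to compound 3 (0.04 log units; within the scatter) is an estimate of no real change. Compound 3 is expected at 32000 nM, range 14000 nM to 70000 nM.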

Compound 3, half-maximal cytotoxic concentration: 28800 nM
Beside the measured number, compound 3's estimate is 1.1-fold (0.05 log units) above it; the measured number falls inside the stated range.
By their numbers in this assay, from the lowest: compounds 3, 1 and 2 (each within the scatter of the next).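

In this assay, nitro in place of fluoro on this aromatic carbon, ortho to a large group, gives a 1.2-fold lower number from compound 2 to compound 3 (0.08 log units; within the scatter) and stays within the scatter. The 2-nitrophenyl for 2-bromo-4-methylphenyl change gives a 1.0-fold lower number from compound 1 to compound 3 (0.01 log units; within the scatter), also within the scatter, so the nitro group, with its hydrogen-bond acceptors, separates from neither fluoro nor bromo and methyl here. No supporting data bear on this result. From the compounds shown here alone, whether an amine or a carboxylic acid on the anilide ring would move the number beyond the scatter remains open.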